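Swapping the aryl group on the amide carbonyl: dimethoxy to difluoro

This account rests on a few compounds, and the source may have more. Where it says the series, first, only, none or still open, it means among the compounds named here.

Compound 1, `O=C(Nc1cccc(-c2oc3cc(-c4ccc(F)cc4)ccc3c(=O)c2O)c1)c1ccc(Br)cc1`, gives 24000 nM in a functional assay on MCF7 cells (Homo sapiens) for antiproliferative activity, read by CCK-8 assay, with a stated time of 72 h; a higher number here means a weaker inhibitor, a lower number a stronger inhibitor.
Compound 2, `COc1cc(OC)cc(C(=O)Nc2cccc(-c3oc4cc(-c5ccc(F)cc5)ccc4c(=O)c3O)c2)c1`, gives 3470 nM in this assay.

Among the two compounds measured so far, compound 2 stands with the lowest number, and the only other compound, compound 1, sits higher by a 6.9-fold lower number from compound 1 to compound 2 (0.84 log units; beyond the scatter). That single step, the replacement of a 4-bromophenyl by a 3,5-dimethoxyphenyl on the carbonyl carbon, is the whole of what is known about this position.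

Compound 3, `O=C(Nc1cccc(-c2oc3cc(-c4ccc(F)cc4)ccc3c(=O)c2O)c1)c1cc(F)cc(F)c1`, is not yet measured. It differs from compound 2 by 3,5-difluorophenyl in place of 3,5-dimethoxyphenyl on a carbonyl carbon. Within the data shown here, no measured step involves a 3,5-difluorophenyl, so the step from compound 1 to compound 2 is the only one that bears on it, and only indirectly: it shows that what hangs on the carbonyl carbon can move the number by a modest amount. With both acceptors of the dimethoxy group gone, the number for compound 3 is expected to move back toward that of compound 1, by roughly a 2.6-fold higher number from compound 2 to compound 3 (0.41 log units; beyond the scatter), though a result within the scatter of compound 2 would not surprise. Compound 3 is therefore estimated at 9000 nM, within a range of 3000 nM to 30000 nM.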

Compound 3, half-maximal inhibitory concentration: 2490 nM
Compound 3: middle estimate off by 3.6-fold (0.56 log units), on the high side; measured number below the stated range.
By their numbers in this assay, from the lowest: compounds 3 and 2 (each within the scatter of the next); then compound 1.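

With a 1.4-fold lower number from compound 2 to compound 3 (0.14 log units; within the scatter), the change on the carbonyl carbon in this assay shows that the 3,5-dimethoxyphenyl, with its hydrogen-bond acceptors, can be exchanged for the 3,5-difluorophenyl, which has none, without a shift beyond the scatter. The 3,5-difluorophenyl also stands apart from the 4-bromophenyl, with a 9.6-fold lower number from compound 1 to compound 3 (0.98 log units; beyond the scatter), so the gap first seen with a 6.9-fold lower number from compound 1 to compound 2 (0.84 log units; beyond the scatter) is not unique to the 3,5-dimethoxyphenyl and appears with both 3,5-disubstituted groups among these three compounds. No measurement is available that explains why the two groups give numbers within the scatter of each other.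

The 4-bromophenyl differs from the other two groups both in its halogen and in where its substituent sits, so these compounds cannot show which of the two differences matters; a 3,5-dibromophenyl or a 4-fluorophenyl would separate them. They also leave open how an unsubstituted phenyl, a 3,5-dimethylphenyl or a non-aromatic group such as a piperidine would behave on the same carbonyl carbon.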